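The source may report more compounds than this note shows. Statements on the series, on what has been measured and on what is new or still open speak of the compounds shown alone.

In a functional assay on A549 cells (Homo sapiens) for antiproliferative activity, read by MTT assay, with a stated time of 72 h (a lower number here means a stronger inhibitor, a higher number a weaker inhibitor), compound 1 (`CCC/C=C/C(=O)Nc1cccc(Oc2nc(Nc3ccn(C)n3)nc3c2CSCC3)c1`) gives 8190 nM and compound 2 (`C/C=C/C(=O)Nc1cccc(Oc2nc(Nc3cccc(C#N)c3)nc3c2CSCC3)c1`) gives 17200 nM. Compound 2 thus holds the higher of the two numbers, with a gap beyond the scatter. Compound 3 (`CCC/C=C/C(=O)Nc1cccc(Oc2nc(Nc3cccc(C#N)c3)nc3c2CSCC3)c1`) departs from compound 2 by one change: ethyl in place of hydrogen on a saturated chain carbon bound to a double-bonded chain carbon. This places ethyl in place of hydrogen on a saturated chain carbon bound to a double-bonded chain carbon, turning prop-1-en-1-yl into pent-1-en-1-yl. Among the measured compounds shown here, no measured pair isolates this change. Compound 1 carries the same (pent-1-en-1-yl)carbonyl and gives 8190 nM, but it also differs from compound 3 in another place. A small move towards a lower number in this assay is expected, possibly none beyond the scatter. The estimated change is a 1.4-fold lower number from compound 2 to compound 3 (0.16 log units; within the scatter). For compound 3 the estimated value is 12000 nM, with an expected range of 5000 nM to 30000 nM.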

Compound 3, half-maximal inhibitory concentration: 5790 nM
The estimate for compound 3 lay 2.1-fold (0.32 log units) above the measured number; measured number inside the range.
By their numbers in this assay, from the lowest: compounds 3 and 1 (each within the scatter of the next); then compound 2.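

The step of a 3.0-fold lower number from compound 2 to compound 3 (0.47 log units; beyond the scatter) in this assay isolates ethyl in place of hydrogen on a saturated chain carbon bound to a double-bonded chain carbon, and shows that this position responds to the change from prop-1-en-1-yl to pent-1-en-1-yl while the 3-cyanophenyl group stays fixed. With pent-1-en-1-yl fixed, the step of a 1.4-fold lower number from compound 1 to compound 3 (0.15 log units; within the scatter) shows that 3-cyanophenyl in place of 1-methyl-1H-pyrazol-3-yl on a nitrogen on an aromatic ring leaves the two numbers indistinguishable in this assay. No evidence on the origin of either step is available.

Among the compounds shown here, only two chain lengths are compared here, so a hept-1-en-1-yl chain or a terminal amine on the chain could extend or reverse the move. From the compounds shown here alone, whether ethyl gives a similar step with 1-methyl-1H-pyrazol-3-yl on the nitrogen also remains open.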